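Ring stereocentre inversion from compound 2 to compound 3

The compounds below may be only part of what the source reports. "The series", "measured", "known", "first", "only" and "open" are said of these compounds alone.

Two compounds carry numbers in a functional assay on NCI-H522 cells (Homo sapiens) for inhibition; on this read-out higher numbers stand for weaker inhibition of growth and lower numbers for stronger inhibition of growth. Compound 1 `CC(=O)CC/C=C(\C)CCC1=C(C)CCCC1(C)C` reaches only the boundary of this assay: its value of > 15000 nM is a limit and not a number, (the limit of > 15000 nM in this assay, at which 1 of the 2 values shown sits). Among the compounds with values here, compound 2 `C=C1CCCC(C)(C)C1CC[C@]1(C)CC[C@@H]([C@@H](C)C(=O)O)OO1` therefore stands as the only compound with a measured number; in this assay compound 2 gives 2060 nM. Compound 3 `C=C1CCCC(C)(C)C1CC[C@@]1(C)CC[C@H]([C@@H](C)C(=O)O)OO1` is not yet measured. It is related to compound 2 as follows: the two compounds have the same atoms and bonds; at least one stereo element is drawn with a configuration in one of them and without one in the other: 2 of 4 stereo elements differ; a stereocentre at a saturated ring carbon is drawn R in compound 2 and S in compound 3; a stereocentre at a saturated ring carbon is drawn S in compound 2 and R in compound 3. Within the data shown here, no step between measured compounds exists in this set, so there is nothing here to calibrate how much a swap of two ring stereocentres moves the number, and the expectation must allow movement in either direction, with a weaker number taken as somewhat more likely than a stronger one. For compound 3 the estimate is 4000 nM, between 1000 nM and 15000 nM, an expected step of a 1.9-fold higher number from compound 2 to compound 3 (0.29 log units; within the scatter).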

Compound 3, concentration for 50% growth inhibition: 1210 nM
Compound 3: middle estimate off by 3.3-fold (0.52 log units), on the high side; low and high end bracket the measured number.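

In this assay, within the data shown here, inverting the two ring stereocentres together gives a 1.7-fold lower number from compound 2 to compound 3 (0.23 log units; within the scatter), the first step that can be read. Compounds 2 and 3 therefore cannot be told apart on this read-out, and the number at this position does not depend on which of these two drawn configurations is present. One caveat applies to assigning the step to configuration alone, as the atoms and bonds are the same: the fact that one of compounds 2 and 3 is drawn with a defined configuration and the other without, at the place where they differ

The compounds shown leave open whether inverting either ring stereocentre alone would give a number within the same scatter, since both change together here. They also leave open how the number responds when the carboxylic acid is replaced by a methyl ester or a primary amide, in either configuration.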